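The compounds below may be only part of what the source reports. "The series", "measured", "known", "first", "only" and "open" are said of these compounds alone.

For the measured compounds named here, compound 2 `COc1ccc2c(c1)OC(c1cc(OC)c(OC)c(OC)c1)C(/C=N/O)=C2` is the one member of the series with a numbered result: in a functional assay for inhibition of nuclear factor NF-kappa-B complex (Homo sapiens) (a lower number here means a stronger inhibitor, a higher number a weaker inhibitor), compound 2 gives 14100 nM. Compound 1 `COc1ccc2c(c1)OC(c1cc(OC)c(OC)c(OC)c1)C(C(=O)N1CCCCC1)=C2` shares the core and differs only at the double-bonded ring carbon. In this assay compound 1 reaches > 50000 nM, which is a limit of the assay and not a number. Going by the values given here, the single measured change at this position is an at least 3.5-fold lower number from compound 1 to compound 2 (0.54 log units; beyond the scatter). Compound 3 `COc1ccc2c(c1)OC(c1cc(OC)c(OC)c(OC)c1)C(C(=O)OC(C)(C)C)=C2` is not yet measured; it differs from compound 2 by a group of 7 heavy atoms (5 carbon, 2 oxygen; no ring) in place of a group of 3 heavy atoms (1 carbon, 1 nitrogen, 1 oxygen; no ring), on a double-bonded ring carbon. Among the compounds with values here, the only step that bears on it is an at least 3.5-fold lower number from compound 1 to compound 2 (0.54 log units; beyond the scatter), and one end of that step sits at the limit of > 50000 nM in this assay, at which 1 of the 2 values shown sits, so the size of the step is known only as a lower bound. Compound 3 moves in the opposite sense to that step, the group that enters being larger than the group that leaves. A higher number in this assay is therefore expected for compound 3, a step of a 2.5-fold higher number from compound 2 to compound 3 (0.39 log units; beyond the scatter), with a fair chance that only the limit is reported. Compound 3 is estimated at 35000 nM, in the range 12000 nM to 100000 nM.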

Compound 3, half-maximal inhibitory concentration: 14100 nM
The estimate for compound 3 lay 2.5-fold (0.39 log units) above the measured number; the measured number falls inside the stated range.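

In this assay, the change from the group of compound 2 to the larger tert-butoxycarbonyl leaves the two compounds level: no change at the digits printed from compound 2 to compound 3 (within the scatter). A larger group on this double-bonded ring carbon therefore does not by itself bring a higher number, and the earlier single step had left that possibility open. The comparison between the two carbonyl compounds, with tert-butoxy in place of piperidin-1-yl, gives an at least 3.5-fold lower number from compound 1 to compound 3 (0.54 log units; beyond the scatter), so the carbonyl alone does not set the weak result of compound 1, and the size of this step stays a lower bound because compound 1 is reported only as a limit of the assay:
the limit of > 50000 nM in this assay, at which 1 of the 3 values shown sits.

Going by these compounds, it remains open whether a free carboxylic acid, a methyl ester or an amide of a smaller amine such as dimethylamine on this carbon would separate from compound 2, at 14100 nM, in either direction. On these data alone, all three compounds share the same core, so the effect of any change away from this carbon, such as a hydroxyl in place of a methoxy group, also remains open.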